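The source may report more compounds than this note shows. Statements on the series, on what has been measured and on what is new or still open speak of the compounds shown alone.

Compound 1 `O[C@@H](c1ccccc1)[C@H]1CO[C@H](c2ccccc2)[C@@H](C/C=C/c2cccc(F)c2)C1`: 8380 nM
Compound 2 `COc1cccc([C@H](O)[C@H]2CO[C@@H](c3ccc(OC)c(OC)c3)[C@H](C/C=C/c3ccc(OC)c(OC)c3)C2)c1`: 18600 nM
Compound 3 `C=CC[C@H]1C[C@@H]([C@@H](O)c2ccccc2)CO[C@@H]1c1ccccc1`: 25400 nM

In a functional assay on HeLa cells (Homo sapiens) for cytotoxicity, read by WST assay, with a stated time of 48 h (a higher number here means a weaker inhibitor, a lower number a stronger inhibitor), compound 1 gives the lowest number of the three; compound 2 sits nearest to it and compound 3 furthest, both beyond the scatter. Compound 4 `O=[N+]([O-])c1cccc(/C=C/C[C@H]2C[C@@H]([C@@H](O)c3ccccc3)CO[C@@H]2c2ccccc2)c1` keeps the core of compound 1 and differs from it by nitro in place of fluoro on an aromatic carbon, so that 3-fluorophenyl becomes 3-nitrophenyl. Among the measured compounds shown here, only one measured step touches this side chain: a 3.0-fold higher number from compound 1 to compound 3 (0.48 log units; beyond the scatter), where the whole 2-(3-fluorophenyl)ethenyl is cut back to vinyl. For the measured compounds named here, no measured pair swaps one group for another on that aromatic ring, so the step to compound 4 has no direct precedent. With the aromatic ring and chain retained, a step of no more than modest size is expected, as a 1.1-fold higher number from compound 1 to compound 4 (0.05 log units; within the scatter). For compound 4 the estimate is 9500 nM, in a range of 4000 nM to 22000 nM.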

Compound 4, half-maximal inhibitory concentration: 7850 nM
Compound 4: middle estimate off by 1.2-fold (0.08 log units), on the high side; the range from low to high includes it.
By their numbers in this assay, from the lowest: compounds 4 and 1 (each within the scatter of the next); then compounds 2 and 3 (each within the scatter of the next).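

In this assay the change from 3-fluorophenyl to 3-nitrophenyl gives a 1.1-fold lower number from compound 1 to compound 4 (0.03 log units; within the scatter) and so shows that this aromatic position takes nitro, with its three heavy atoms and two hydrogen-bond acceptors, with no change beyond the scatter. The earlier compounds shown here showed only that cutting the whole side chain back to vinyl gives a 3.0-fold higher number from compound 1 to compound 3 (0.48 log units; beyond the scatter) and said nothing about exchanging the group on that ring. No measurement given here explains this result. As far as these compounds go, whether an amine or a carboxylic acid at the same position would also leave the number within the scatter remains open.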